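Swapping Thiophene for Furan on the Amide Carbonyl

This account rests on a few compounds, and the source may have more. Where it says the series, first, only, none or still open, it means among the compounds named here.

Measured compounds:
- compound 1 `CC(C)C[C@H](NC(=O)c1cc2ccccc2[nH]1)C(=O)N[C@H]1CCN(Cc2ccc(OCCCN(C)C)cc2)C1`, in an assay on HEK293 cells for binding affinity to Urotensin-2 receptor (Homo sapiens), read by radioligand binding (on this read-out higher numbers stand for weaker inhibition and lower numbers for stronger inhibition), compound 1 gives 501 nM
- compound 2 `CC(C)C[C@H](NC(=O)c1cccs1)C(=O)N[C@H]1CCN(Cc2ccc(OCCCN(C)C)cc2)C1`, in this assay compound 2 gives 398 nM

Among the measured compounds shown here, compound 2 carries the lower of the two numbers, but the only measured step, a 1.3-fold lower number from compound 1 to compound 2 (0.10 log units; within the scatter), lies within the scatter, so neither compound can be called stronger than the other. That step exchanged one aromatic ring for another on the carbonyl carbon, and the number hardly moved.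

Compound 3 `CC(C)C[C@H](NC(=O)c1ccco1)C(=O)N[C@H]1CCN(Cc2ccc(OCCCN(C)C)cc2)C1` is not yet measured. It differs from compound 2 by furan-2-yl in place of thiophen-2-yl on a carbonyl carbon. For the measured compounds named here, the only measured step bears on it directly, since it also swaps the ring on that carbonyl carbon, and it was small. For compound 3 the expected step is therefore a 1.1-fold higher number from compound 2 to compound 3 (0.05 log units; within the scatter), that is, nothing beyond the scatter. Compound 3 is estimated at 450 nM, with a range from 200 nM to 1000 nM.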

Compound 3, inhibition constant: 631 nM
Estimate against measurement, compound 3: 1.4-fold (0.15 log units) below, within the range that was stated.
By their numbers in this assay, from the lowest: compounds 2, 1 and 3 (each within the scatter of the next).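

Furan-2-yl in place of thiophen-2-yl on the carbonyl carbon gives a 1.6-fold higher number from compound 2 to compound 3 (0.20 log units; within the scatter) in this assay and furan-2-yl in place of 1H-indol-2-yl gives a 1.3-fold higher number from compound 1 to compound 3 (0.10 log units; within the scatter) in the same read-out. With three aromatic groups now on this carbonyl carbon, all three steps among them stay within the scatter, so this read-out does not separate these groups, even for the exchange of sulfur for oxygen in the ring. No separate measurement bears on this result.

From the compounds shown here alone, it remains open whether a group without an aromatic ring on this carbonyl carbon, such as cyclohexyl or a plain alkyl chain, would also leave the number within the scatter. Going by these compounds, it is also open whether a ring carrying an amine or a carboxylic acid would do the same.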